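Series notes: ether substituent and kinetic solubility

This account rests on a few compounds, and the source may have more. Where it says the series, first, only, none or still open, it means among the compounds named here.

Measured so far:
compound 1 `Nc1nccc(-c2cc(OC3CCOC3)c3c(N)n[nH]c3c2)n1` — 751000 nM
compound 2 `Nc1nccc(-c2cc(OCc3ccccc3)c3c(N)n[nH]c3c2)n1` — 85000 nM
compound 3 `Nc1nccc(-c2cc(OC3CCCOC3)c3c(N)n[nH]c3c2)n1` — 1000000 nM

In a physicochemical assay for solubility, read by LC-MS, in phosphate buffer, measured as kinetic solubility, with a stated time of 24 h, at 25 degrees C, at pH 7.4 (a higher number here means a more soluble compound, a lower number a less soluble compound), compound 3 gives 1000000 nM, the highest of the three numbers. Compound 1 sits close to it (a 1.3-fold higher number from compound 1 to compound 3 (0.12 log units; within the scatter)), whereas compound 2 is far below (a 12-fold higher number from compound 2 to compound 3 (1.07 log units; beyond the scatter)). The step of an 8.8-fold lower number from compound 1 to compound 2 (0.95 log units; beyond the scatter) points the same way.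

Compound 4 `Nc1nccc(-c2cc(Oc3ccccc3)c3c(N)n[nH]c3c2)n1` differs from compound 3 by phenyl in place of oxan-3-yl on an oxygen on an aromatic ring. Among the measured compounds shown here, the only measured steps that bear on this change are those that swap a saturated oxygen heterocycle for an aromatic carbon ring: from compound 1 to compound 2 and from compound 2 to compound 3, both beyond the scatter. For the measured compounds named here, no measured step separates phenyl from benzyl directly, so the exact size is uncertain, but a step of the same order, in the downward direction, is expected for this assay.

For compound 4 the expected step from compound 3 is an 11-fold lower number from compound 3 to compound 4 (1.05 log units; beyond the scatter), giving an estimated value of 90000 nM in this assay, within a range of 30000 nM to 300000 nM.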

Compound 4, solubility: 117000 nM
Beside the measured number, compound 4's estimate is 1.3-fold (0.11 log units) below it, and the stated range covers the measured number.
By their numbers in this assay, from the lowest: compounds 2 and 4 (each within the scatter of the next); then compounds 1 and 3 (each within the scatter of the next).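

In this assay, phenyl and benzyl on the oxygen cannot be told apart, with a 1.4-fold higher number from compound 2 to compound 4 (0.14 log units; within the scatter). Phenyl stands clearly apart from both saturated rings, with an 8.5-fold lower number from compound 3 to compound 4 (0.93 log units; beyond the scatter) and a 6.4-fold lower number from compound 1 to compound 4 (0.81 log units; beyond the scatter). Across these four compounds, the ethers therefore fall into two sets, oxan-3-yl and oxolan-3-yl on one side and the two carbon-only aromatic rings on the other, and no compound goes against this split.

No supporting measurement explains the gap between the two sets. From the compounds shown here alone, it remains open where a pyridyl ring, an aromatic ring carrying a nitrogen, or an open-chain ether such as 2-methoxyethyl would fall, and so whether the split follows the ring oxygen, aromaticity or something else.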